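The source may hold more compounds than are shown below. What is called first, only, known or untested is meant among the compounds shown, and "the series" means these compounds.

Measured so far:
compound 1 `COc1ccc(Sc2ccc(Cl)cc2N2CCN(CC(=O)O)C(C)C2)cc1` gives 290 nM in an assay for inhibition of sodium- and chloride-dependent glycine transporter 1 (Homo sapiens); a higher number here means a weaker inhibitor, a lower number a stronger inhibitor
compound 2 `COc1ccc(Sc2ccc(C)cc2N2CCN(CC(=O)O)C(C)C2)cc1` gives 1600 nM in this assay
compound 3 `Cc1ccc(Sc2ccccc2N2CC(C)N(CC(=O)O)CC2C)cc1` gives 550 nM in this assay

Compound 2 and compound 1 differ only by chloro in place of methyl on an aromatic carbon, and that change brought a 5.5-fold lower number from compound 2 to compound 1 (0.74 log units; beyond the scatter). Compound 3 stands on a different core; the difference between the cores of compound 3 and compound 2 is not broken down here. Compound 4 `CC1CN(c2ccccc2Sc2ccc(Cl)cc2)C(C)CN1CC(=O)O` carries the same kind of change against compound 3, namely (chloro in place of methyl on an aromatic carbon). The surroundings are not the same, though: in the earlier pair the place is meta to a large group and para to a (4-methoxyphenyl)sulfanyl group, whereas here it is para to a large group. Among the measured compounds shown here, because the earlier pair showed a 5.5-fold lower number from compound 2 to compound 1 (0.74 log units; beyond the scatter), a step of similar direction is expected, a 2.8-fold lower number from compound 3 to compound 4 (0.44 log units; beyond the scatter), though with a broad range since only one example supports it. Compound 4 is therefore estimated at 200 nM, between 60 nM and 700 nM.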

Compound 4, half-maximal inhibitory concentration: 360 nM
Compound 4: the middle estimate sits 1.8-fold (0.26 log units) below what was measured; the range from low to high includes it.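

In this assay, chloro in place of methyl gave a 1.5-fold lower number from compound 3 to compound 4 (0.18 log units; within the scatter), so on this core the change cannot be told apart from the ordinary spread of repeat measurements. The size of the step therefore did not carry over from one core to the other: the same change on two cores in this assay, a 5.5-fold lower number (0.74 log units; beyond the scatter) from compound 2 to compound 1 and a 1.5-fold lower number (0.18 log units; within the scatter) from compound 3 to compound 4, 3.6-fold (0.56 log units) apart, beyond the scatter of two such steps

These two pairs do not show which difference between the cores sets the size of the step, and they cannot establish a shared direction, since only the first step lies beyond the scatter. The compounds shown leave open how a fluoro or a nitrile in the same place would compare with chloro and methyl on each core. They also leave open whether an amide could stand in for the carboxylic acid.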